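Swapping a Hydroxycyclohexyl for an Aminopropyl on Sulfur

The source may hold more compounds than are shown below. What is called first, only, known or untested is meant among the compounds shown, and "the series" means these compounds.

Of the compounds shown here, three sharing one core have been tested in a functional assay on HT cells (Homo sapiens) for antiproliferative activity, read by fluorescence, with a stated time of 72 h; on this read-out lower numbers stand for stronger inhibition of growth and higher numbers for weaker inhibition of growth. Compound 1 `CC(C)c1n[nH]c2c(NCc3ccc(-c4ccccn4)cc3)nc(SCC3CNC(=O)O3)nc12` gives 80 nM, compound 2 `CC(C)c1n[nH]c2c(NCc3ccc(-c4ccccn4)cc3)nc(SCCCN(C)C)nc12` gives 105 nM, and compound 3 `CC(C)c1n[nH]c2c(NCc3ccc(-c4ccccn4)cc3)nc(SC3CCCCC3O)nc12` gives 636 nM, the highest of the three numbers: an 8.0-fold higher number from compound 1 to compound 3 (0.90 log units; beyond the scatter) and a 6.1-fold higher number from compound 2 to compound 3 (0.78 log units; beyond the scatter), whereas a 1.3-fold higher number from compound 1 to compound 2 (0.12 log units; within the scatter). Compound 4 `CC(C)c1n[nH]c2c(NCc3ccc(-c4ccccn4)cc3)nc(SCCCN)nc12` alters compound 3 at the sulfur: 3-aminopropyl in place of 2-hydroxycyclohexyl on a sulfur. The measured step that bears most on this is a 6.1-fold higher number from compound 2 to compound 3 (0.78 log units; beyond the scatter); the 3-aminopropyl group that enters resembles the 3-(dimethylamino)propyl of compound 2 far more than the 2-hydroxycyclohexyl it replaces. Undoing that change is expected to bring a step of roughly the same size back down, a 4.9-fold lower number from compound 3 to compound 4 (0.69 log units; beyond the scatter), in this assay. Compound 4 is therefore estimated at 130 nM, most likely between 50 nM and 350 nM.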

Compound 4, concentration for 50% growth inhibition: 120 nM
Compound 4: middle estimate off by 1.1-fold (0.03 log units), on the high side; the range from low to high includes it.
By their numbers in this assay, from the lowest: compounds 1, 2 and 4 (each within the scatter of the next); then compound 3.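

Placing 3-aminopropyl on the sulfur in place of 2-hydroxycyclohexyl gives a clear gain (a 5.3-fold lower number from compound 3 to compound 4 (0.72 log units; beyond the scatter)), so a second amine-ended chain now stands apart from the ring-bearing group. Amino in place of dimethylamino changes nothing readable (a 1.1-fold higher number from compound 2 to compound 4 (0.06 log units; within the scatter)), and the chain also stays level with the 2-oxo-1,3-oxazolidin-5-yl group (a 1.5-fold higher number from compound 1 to compound 4 (0.18 log units; within the scatter)). Nothing shown explains these steps.

As far as these compounds go, whether a carboxylic acid at the chain end or a longer chain such as 4-aminobutyl would hold this level stays open. So does whether plain cyclohexyl, without the hydroxyl, would behave like compound 3.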